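The compounds below may be only part of what the source reports. "The series", "measured", "known", "first", "only" and "open" are said of these compounds alone.

In a functional assay on DU-145 cells (Homo sapiens) for cytotoxicity, read by sulforhodamine B assay, with a stated time of 48 h (on this read-out higher numbers stand for weaker inhibition of growth and lower numbers for stronger inhibition of growth), the three measured compounds stand as follows:

compound 1 `N#Cc1ccc(Nc2nc(Oc3ccnc4ccccc34)nc(N3CCN(c4cccc(C(F)(F)F)c4)CC3)n2)cc1C(F)(F)F`: 38700 nM
compound 2 `COc1ccc(N2CCN(c3nc(Nc4ccc(C#N)c(C(F)(F)F)c4)nc(Oc4ccnc5ccccc45)n3)CC2)cc1`: > 100000 nM, a limit of the assay
compound 3 `CC(C)N1CCN(c2nc(Nc3ccc(C#N)c(C(F)(F)F)c3)nc(Oc3ccnc4ccccc34)n2)CC1`: > 100000 nM, a limit of the assay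

Compound 3 therefore has no number in this assay; its value of > 100000 nM is a limit and nothing more. Compound 1 is the only one of the three with a measured number, 38700 nM. The step of an at least 2.5-fold higher number from compound 1 to compound 3 (0.41 log units; beyond the scatter) shows that putting isopropyl on the ring nitrogen in place of the aryl group weakened growth inhibition by an amount that is at least modest. The step that the two limits leave unreadable from compound 2 to compound 3 cannot be sized, because both of its ends sit at the limit (the limit of > 100000 nM in this assay, at which 2 of the 3 values shown sit).

Compound 4 `N#Cc1ccc(Nc2nc(Oc3ccnc4ccccc34)nc(N3CCN(Cc4ccccc4)CC3)n2)cc1C(F)(F)F` differs from compound 3 in one place: benzyl in place of isopropyl on an amine nitrogen in a ring. Benzyl brings back an aromatic ring, as in compound 1, though attached through a carbon rather than directly on the ring nitrogen; no measured step covers exactly this change. Compound 4 is therefore expected to land somewhere between compound 1 and the limit, most likely still weak. For compound 4 the estimate is 70000 nM, with a range from 20000 nM to 200000 nM. This corresponds to an expected step of an at least 1.4-fold lower number from compound 3 to compound 4 (0.15 log units; that floor lies within the scatter).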

Compound 4, concentration for 50% growth inhibition: > 100000 nM
Compound 4 gave a limit, no number; the forecaster's own chance of this, stated with the estimate: 45%; at least 1.4-fold (0.15 log units) between middle value and limit.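

In this assay, the new result shows that an aromatic ring carried on this ring nitrogen is not enough by itself to give a measured number: benzyl in place of 3-(trifluoromethyl)phenyl gives an at least 2.5-fold higher number from compound 1 to compound 4 (0.41 log units; beyond the scatter). With 4-methoxyphenyl, isopropyl and now benzyl all at the limit, three different groups at this place give no number, and among the compounds shown only the 3-(trifluoromethyl)phenyl of compound 1 stands clear of it: the limit of > 100000 nM in this assay, at which 3 of the 4 values shown sit. The steps among compound 2, compound 3 and compound 4 cannot be read, so no order can be given among 4-methoxyphenyl, isopropyl and benzyl.

The compounds shown leave open whether a plain phenyl, a 3-chlorophenyl or a 4-(trifluoromethyl)phenyl on this nitrogen would also give a number, and so whether the trifluoromethyl group or its place on the phenyl ring goes with the value of compound 1. They also leave open whether a longer chain ending in an aromatic ring, such as 2-phenylethyl, would behave like benzyl in this assay.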